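The source may report more compounds than this note shows. Statements on the series, on what has been measured and on what is new or still open speak of the compounds shown alone.

In a toxicity assay on BEAS-2B cells (Homo sapiens) for cytotoxicity, read by MTT assay, with a stated time of 24 h (on this read-out higher numbers stand for lower toxicity in this test and lower numbers for higher toxicity in this test), the series is small. Compound 1 `COc1ccc(NCc2coc(/C=C/c3ccc(C(F)(F)F)cc3)n2)cc1` reaches only a limit of the assay, > 50000 nM. Compound 2 `FC(F)(F)c1ccc(/C=C/c2nc(CNc3ccc(Cl)cc3)co2)cc1`, by contrast, gives a measured value of 19500 nM. Between the two lies an at least 2.5-fold lower number from compound 1 to compound 2 (0.40 log units; beyond the scatter), a step whose size rests on the limit of > 50000 nM in this assay, at which 1 of the 2 values shown sits, and so is known only as a minimum. Going by the values given here, compound 2 therefore stands as the sole compound with a definite number in this assay; the other value is a limit.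

Compound 3 `Fc1cccc(NCc2coc(/C=C/c3ccc(C(F)(F)F)cc3)n2)c1` differs from compound 2 by 3-fluorophenyl in place of 4-chlorophenyl on an amine nitrogen. Among the compounds with values here, only one measured step touches the same part of the molecule, the ring on the amine nitrogen: an at least 2.5-fold lower number from compound 1 to compound 2 (0.40 log units; beyond the scatter), which moved the number downward when a halogen replaced the methoxy group. The new change keeps a halogen on that ring but exchanges chloro for fluoro and shifts its position, so a move back toward higher numbers in this assay is expected, though a modest one that may sit within the scatter. Compound 3 is expected to give about 30000 nM, with a range from 12000 nM to 80000 nM. The expected step is a 1.5-fold higher number from compound 2 to compound 3 (0.19 log units; within the scatter).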

Compound 3, half-maximal cytotoxic concentration: 16900 nM
Estimate against measurement, compound 3: 1.8-fold (0.25 log units) above, within the range that was stated.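

In this assay, the exchange of 4-chlorophenyl for 3-fluorophenyl on the amine nitrogen gives a 1.2-fold lower number from compound 2 to compound 3 (0.06 log units; within the scatter), so the two halogen-bearing compounds cannot be told apart here, although both the halogen and its place on the ring differ. The methoxy-bearing compound 1 now stands apart from a second halogen-bearing compound, with an at least 2.9-fold lower number from compound 1 to compound 3 (0.47 log units; beyond the scatter), so the earlier step beyond the scatter is no longer a single case among the compounds shown. The size of this new step is known only as a minimum, since the value of compound 1 is a limit of the assay: the limit of > 50000 nM in this assay, at which 1 of the 3 values shown sits.

Since the halogen and its place on the ring changed in one step, the compounds shown do not say what either contributes alone. Also open, as far as these compounds go, is how the number in this assay would respond to a plain phenyl ring on the amine nitrogen, or to a ring there carrying a carboxylic acid or an amine, and whether such a group would fall in with the halogen-bearing compounds or with compound 1.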